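A tert-butyl in place of ethyl on compound 2

A few compounds are considered here, and "the series" means these few. Any claim that something is new, unique, unknown or untested is made for them only; others in the source may bear on it.

Compound 1 `CCOC(=O)c1cc(N2C(=O)C3=C(CCCC3)C2=O)c(F)cc1Cl`: 100 nM
Compound 2 `CCOC(=O)c1cc(N2C(=O)C3=C(CCCC3)C2=O)ccc1Cl`: 1380 nM
Compound 3 `CCC(C)OC(=O)c1cc(N2C(=O)C3=C(CCCC3)C2=O)c(F)cc1Cl`: 24.6 nM

These values come from a functional assay on the whole organism with Scenedesmus acutus as the target; on this read-out higher numbers stand for weaker inhibition and lower numbers for stronger inhibition. Among the three compounds, compound 2 has the highest number, at 1380 nM, which means the weakest inhibition. The closest value belongs to compound 1, and the gap is a 14-fold higher number from compound 1 to compound 2 (1.14 log units; beyond the scatter). Compound 4 `CC(C)(C)OC(=O)c1cc(N2C(=O)C3=C(CCCC3)C2=O)ccc1Cl` differs from compound 2 by tert-butyl in place of ethyl on an oxygen next to a carbonyl group, with tert-butyl in place of ethyl on an oxygen next to a carbonyl group. The fluoro-to-hydrogen step does not recur here, so it only sets the starting level. The nearest evidence is a 4.1-fold lower number from compound 1 to compound 3 (0.61 log units; beyond the scatter), which also alters the chain on that oxygen but in compounds carrying fluoro. Among the compounds with values here, no measured compound carries tert-butyl, and none shows such a chain change with hydrogen in place of fluoro. A modest step towards a lower number is therefore expected, though with real uncertainty. The expected change is a 2.8-fold lower number from compound 2 to compound 4 (0.44 log units; beyond the scatter). For compound 4, the estimated value is 500 nM, with an expected range of 150 nM to 1800 nM.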

Compound 4, half-maximal inhibitory concentration: 12900 nM
Compound 4: the middle estimate sits 26-fold (1.41 log units) below what was measured, outside the stated range (above it).
By their numbers in this assay, from the lowest: compound 3; then compound 1; then compound 2; then compound 4.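

In this assay, the chain on an oxygen next to a carbonyl group can push the number up as well as down: tert-butyl in place of ethyl gives a 9.3-fold higher number from compound 2 to compound 4 (0.97 log units; beyond the scatter), whereas the earlier chain change on that oxygen gave a 4.1-fold lower number from compound 1 to compound 3 (0.61 log units; beyond the scatter). A larger chain here therefore does not lead to a lower number in every case, although the two steps stand in compounds that differ by fluoro or hydrogen on an aromatic carbon. Nothing measured in the material at hand accounts for this reversal.

The compounds shown leave open whether tert-butyl would raise the number as far in compound 1, which carries fluoro. They also leave open how an isopropyl chain, or a free carboxylic acid in place of the ester, would read in this assay.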